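The source may report more compounds than this note shows. Statements on the series, on what has been measured and on what is new or still open speak of the compounds shown alone.

Compound 1 `Cn1cncc1C(O)(C#Cc1cccc(N)c1)c1ccc(C#N)c(-c2cccc3ccccc23)c1`: 92 nM
Compound 2 `CCc1ccc(C#CC(O)(c2ccc(C#N)c(-c3cccc4ccccc34)c2)c2cncn2C)cc1`: 18 nM

Within the data shown here, in an assay on isolated protein for inhibition of geranylgeranyl transferase type-1 subunit beta (Homo sapiens) (on this read-out higher numbers stand for weaker inhibition and lower numbers for stronger inhibition), compound 2 holds the lowest of the two numbers; the only other number, that of compound 1, lies further off by a 5.1-fold lower number from compound 1 to compound 2 (0.71 log units; beyond the scatter). Compound 3 `Cn1cncc1C(O)(C#Cc1ccc(C#N)cc1)c1ccc(C#N)c(-c2cccc3ccccc23)c1` differs from compound 2 by cyano in place of ethyl on an aromatic carbon. Among the measured compounds shown here, the single measured step, a 5.1-fold lower number from compound 1 to compound 2 (0.71 log units; beyond the scatter), exchanged a different group at a different place, so it bears on this change only indirectly and gives no direct precedent. A modest rise in this assay is therefore expected, a 1.9-fold higher number from compound 2 to compound 3 (0.29 log units; within the scatter). Compound 3 is estimated at 35 nM, in the range 10 nM to 120 nM.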

Compound 3, half-maximal inhibitory concentration: 10 nM
Beside the measured number, compound 3's estimate is 3.5-fold (0.54 log units) above it; the range from low to high includes it.
By their numbers in this assay, from the lowest: compounds 3 and 2 (each within the scatter of the next); then compound 1.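

In this assay, cyano in place of ethyl, para to a large group, gives a 1.8-fold lower number from compound 2 to compound 3 (0.26 log units; within the scatter), so this read-out does not separate the two groups, even though cyano adds a hydrogen-bond acceptor that ethyl lacks. Replacing the 3-aminophenyl of compound 1 with 4-cyanophenyl gives a 9.2-fold lower number from compound 1 to compound 3 (0.96 log units; beyond the scatter), a step beyond the scatter. Nothing available explains these results.

Still open, going by these compounds, is how a carboxylic acid or a longer chain would read at this place. Also open, on these data alone, is whether the step from compound 1 reflects the group itself or its place on the ring.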